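Swapping an Acetoxy Group for a Hydroxy Group

A few compounds are considered here, and "the series" means these few. Any claim that something is new, unique, unknown or untested is made for them only; others in the source may bear on it.

Of the compounds shown here, three have been measured so far. In a functional assay on HT-29 cells (Homo sapiens) for inhibition (on this read-out higher numbers stand for weaker inhibition and lower numbers for stronger inhibition), compound 1 `COc1cc2ccc(CCc3ccc4ccccc4c3)cc2cc1O` gives 3590 nM. Compound 2 `COCCOc1cc(/C=C\c2ccc3ccccc3c2)ccc1OC` gives 2990 nM, and the two values lie within the usual scatter of each other.

For compound 3 `CC(=O)Oc1ccc(/C=C/c2ccc3ccccc3c2)cc1`, the same measurement yields only a limit, > 5000 nM, and not a number.

The next compound, compound 4 `Oc1ccc(/C=C/c2ccc3ccccc3c2)cc1`, differs from compound 3 in a single place. It carries hydrogen in place of acetyl on an oxygen on an aromatic ring, which reads as acetoxy to hydroxy (hydrogen in place of acetyl on an oxygen on an aromatic ring). For the measured compounds named here, no pair of measured compounds shows what this change does, so any forecast for this assay is a cautious one.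

Going by the values given here, the only numerical anchors are compound 1 at 3590 nM and compound 2 at 2990 nM. A modest move toward stronger inhibition, into the same region as those two, is therefore expected, though a second limit would be no surprise. The estimated change is small, an at least 1.1-fold lower number from compound 3 to compound 4 (0.04 log units; that floor lies within the scatter). For compound 4 the expected value is 4500 nM, with an estimated range from 1800 nM to 9000 nM.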

Compound 4, half-maximal inhibitory concentration: 4060 nM
For compound 4 the middle estimate is 1.1-fold (0.04 log units) above the measured one; the measured number falls inside the stated range.
By their numbers in this assay, from the lowest: compounds 2, 1 and 4 (each within the scatter of the next). At a limit, above all of these: compound 3.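

For the compounds shown here, this step is the first reading of what happens at this place, on an oxygen on an aromatic ring: in this assay, putting hydrogen in place of acetyl gives an at least 1.2-fold lower number from compound 3 to compound 4 (0.09 log units; that floor lies within the scatter). That floor lies within the usual scatter, so the step on its own does not establish a real gain in inhibition, although it leaves room for a larger change that the data cannot size. The true size of the step stays hidden, and only this floor can be stated, because compound 3 stands at a limit and not at a number: the limit of > 5000 nM in this assay, at which 1 of the 4 values shown sits.

On these data alone, compound 1 and compound 2 differ from compound 4 in more than one place, so they cannot show whether the same swap would behave alike on another core, and how far compound 3 really lies from compound 4 also remains open. The compounds shown likewise leave open what an amine, a carboxylic acid or a longer chain would do at this oxygen or in place of the hydroxy group.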